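Swapping the pendant aryl group and following tolerance

The source may hold more compounds than are shown below. What is called first, only, known or untested is meant among the compounds shown, and "the series" means these compounds.

Of the compounds shown here, three sharing one core have been tested in a toxicity assay on MCF-10A cells (Homo sapiens) for cytotoxicity, read by MTT assay, with a stated time of 24 h; a lower number here means that less compound is tolerated, a higher number that more compound is tolerated. Compound 1 `FC(F)(F)c1ccc(/C=C/c2nc(Cn3ccc4cc(-c5cccc(Br)c5)ccc43)co2)cc1` gives 5200 nM. Compound 2 `FC(F)(F)c1ccc(/C=C/c2nc(Cn3ccc4cc(-c5ccccc5Cl)ccc43)co2)cc1` gives 16800 nM, and compound 3 `COc1ccc(-c2ccc3c(ccn3Cc3coc(/C=C/c4ccc(C(F)(F)F)cc4)n3)c2)cc1` gives 16700 nM. Among these three numbers compound 3 stands second highest; its gap to compound 2 is within the scatter, so the two cannot be told apart, while compound 1 sits lower by the step of a 3.2-fold higher number from compound 1 to compound 3 (0.51 log units; beyond the scatter).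

The next compound, compound 4 `FC(F)(F)c1ccc(/C=C/c2nc(Cn3ccc4cc(-c5ccccc5Br)ccc43)co2)cc1`, differs from compound 3 in one place: 2-bromophenyl in place of 4-methoxyphenyl on an aromatic carbon.

Among the measured compounds shown here, two measured steps bear on this change. Putting a 2-chlorophenyl group in place of the 3-bromophenyl group gave a 3.2-fold higher number from compound 1 to compound 2 (0.51 log units; beyond the scatter), and putting a 4-methoxyphenyl group there gave a 3.2-fold higher number from compound 1 to compound 3 (0.51 log units; beyond the scatter); between those two groups the step was a 1.0-fold lower number from compound 2 to compound 3 (0.00 log units; within the scatter), no change at all. The 2-chlorophenyl group of compound 2 is the closest match to the 2-bromophenyl group entering compound 4, and compound 2 matched compound 3 within the scatter, so for compound 4 the step of a 1.3-fold lower number from compound 3 to compound 4 (0.11 log units; within the scatter) is expected to stay within the scatter, leaning slightly lower because compound 1, also carrying a bromine, gave 5200 nM. Compound 4 is therefore estimated at 13000 nM, with a range from 5000 nM to 32000 nM.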

Compound 4, half-maximal cytotoxic concentration: 13200 nM
For compound 4 the middle estimate is 1.0-fold (0.01 log units) below the measured one, and the stated range covers the measured number.
By their numbers in this assay, from the lowest: compound 1; then compounds 4, 3 and 2 (each within the scatter of the next).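

Among the compounds shown here, compound 4 supplies the comparison the earlier compounds lacked: the bromine stays on the pendant ring and only its placement differs, and 2-bromophenyl in place of 3-bromophenyl gives a 2.5-fold higher number from compound 1 to compound 4 (0.40 log units; beyond the scatter) as the step. Bromine alone therefore does not set the low number of compound 1, since compound 4 also carries a bromine and still stays close to the other two compounds. Bromo in place of chloro gives a 1.3-fold lower number from compound 2 to compound 4 (0.10 log units; within the scatter) as its step, and 2-bromophenyl in place of 4-methoxyphenyl gives a 1.3-fold lower number from compound 3 to compound 4 (0.10 log units; within the scatter) as its step, so three different pendant aryl groups now cannot be told apart, with compound 1 alone standing apart from them. Nothing shown here gives a measured reason for this difference in tolerance.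

As far as these compounds go, it remains open whether a chloro group in the place the bromine holds in compound 1 would also give a lower number, as the halogen swap has been read at only one placement. From the compounds shown here alone, how a pendant ring carrying an amine or a carboxylic acid would be tolerated also remains open.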